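The compounds below may be only part of what the source reports. "The series", "measured", "known", "first", "only" and "open" are said of these compounds alone.

Compound 2 `CC1=CC[C@H](C(C)C)c2cc(C)c(OC(=O)c3ccc(Cl)cc3)cc21` and compound 1 `CC1=CC[C@H](C(C)C)c2cc(C)c(OC(=O)c3ccc([N+](=O)[O-])cc3)cc21` share the same core and differ only in the aromatic ring attached to the ester carbonyl. In a functional assay on HCT-15 cells (Homo sapiens) for antiproliferative activity, read by sulforhodamine B assay, with a stated time of 48 h, tested at 50 uM (on this read-out higher numbers stand for more inhibition at the one concentration tested (going by the name of the read-out) and lower numbers for less inhibition), compound 1 gives 67.8%, and compound 2 gives 47.4%. Within the data shown here, of these two numbers compound 2 holds the lower one, and the drop a number 20.4 percentage points lower from compound 1 to compound 2 (beyond the scatter) is the only measured step so far.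

Compound 3 `CC1=CC[C@H](C(C)C)c2cc(C)c(OC(=O)c3cccc([N+](=O)[O-])c3)cc21` has not yet been measured. It differs from compound 2 in one place: 3-nitrophenyl in place of 4-chlorophenyl on a carbonyl carbon. A nitro-bearing ring thus returns, although as 3-nitrophenyl, which is not the ring of compound 1, so the earlier step is only a rough guide.

Since a number 20.4 percentage points lower from compound 1 to compound 2 (beyond the scatter) fell when chloro replaced nitro, a rise of comparable size is expected in this assay when a nitrophenyl comes back. Compound 3 is therefore expected to give about 62%, within 45% to 78%. That estimate corresponds to an expected step of a number 14.6 percentage points higher from compound 2 to compound 3 (beyond the scatter) in this assay.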

Compound 3, a percentage reported as inhibition, at one concentration (the size of the read-out at that concentration, not a potency): 45.9%
Beside the measured number, compound 3's estimate is 16.1 percentage points above it; measured number inside the range.
By their numbers in this assay, from the lowest: compounds 3 and 2 (each within the scatter of the next); then compound 1.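

Bringing a nitro group back does not by itself bring back the higher number in this assay, since 3-nitrophenyl in place of 4-chlorophenyl gives a number 1.5 percentage points lower from compound 2 to compound 3 (within the scatter) and these two rings cannot be told apart here. The two nitro rings do differ, with 3-nitrophenyl in place of 4-nitrophenyl giving a number 21.9 percentage points lower from compound 1 to compound 3 (beyond the scatter), so among these three compounds only compound 1, with its 4-nitrophenyl, stands apart, and the presence of a nitro group alone does not account for that. No supporting measurement is available to explain why the two nitro rings differ.

The compounds shown leave open whether the higher number of compound 1 is special to the nitro group. A phenyl ring carrying an amine or a carboxylic acid in that same ring position could test this.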